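This account rests on a few compounds, and the source may have more. Where it says the series, first, only, none or still open, it means among the compounds named here.

Measured compounds in a functional assay on A-375 cells (Homo sapiens) for inhibition, read by CCK-8 assay, with a stated time of 72 h, tested at 2 uM; a lower number here means less inhibition of growth, a higher number more inhibition of growth at the concentration tested:
- compound 1 `COc1ccc(SCc2ccc(/C=C/C(=O)Nc3ccccc3N)cc2)cc1OC`: 46%
- compound 2 `Cc1ccc(SCc2ccc(C(=O)Nc3ccccc3N)cc2)cc1`: 17.5%
- compound 3 `CC(C)(C)c1ccc(SCc2ccc(C(=O)Nc3ccccc3N)cc2)cc1`: 2.13%

Compound 1 stands highest of the three numbers; compound 2 is the nearest and compound 3 the furthest, both beyond the scatter. Compound 4 `Nc1ccccc1NC(=O)/C=C/c1ccc(CSc2ccc(C(F)(F)F)cn2)cc1` is not yet measured. It differs from compound 1 by 5-(trifluoromethyl)pyridin-2-yl in place of 3,4-dimethoxyphenyl on a sulfur.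

Among the measured compounds shown here, the only single-place step in hand, a number 15.4 percentage points lower from compound 2 to compound 3 (beyond the scatter), is a change on the aromatic ring attached to the sulfur, as is the change from compound 1 to compound 4, but it alters a substituent rather than exchanging the whole ring, so it is a loose guide at most. Compound 1 and compound 2 differ in more than one place; their values show only that the series spans a wide range.

Given that the sole comparable step lowered the number modestly, a downward shift is expected for compound 4, estimated as a number 14 percentage points lower from compound 1 to compound 4 (beyond the scatter). Compound 4 is expected to give 32%, between 12% and 52%.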

Compound 4, percent growth inhibition at one concentration: 10.3%
Compound 4: the middle estimate sits 21.7 percentage points above what was measured; the measured number lies below the stated range.
By their numbers in this assay, from the lowest: compounds 3, 4 and 2 (each within the scatter of the next, the first and the last beyond it); then compound 1.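

In this assay, among the compounds shown here, the earlier compounds showed only a substituent change on the ring attached to the sulfur, a number 15.4 percentage points lower from compound 2 to compound 3 (beyond the scatter). Exchanging the whole ring on the core of compound 1 gives a number 35.7 percentage points lower from compound 1 to compound 4 (beyond the scatter), so 5-(trifluoromethyl)pyridin-2-yl does not keep the level of 3,4-dimethoxyphenyl at this sulfur. No measured information on the compounds bears on this step.

The compounds shown do not separate the ring nitrogen from the trifluoromethyl group in this step. As far as these compounds go, how a plain pyridin-2-yl or a phenyl carrying trifluoromethyl would read on the same sulfur remains open.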